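Swapping the Ring Amine on the Aniline of Compound 2

The compounds below may be only part of what the source reports. "The series", "measured", "known", "first", "only" and "open" are said of these compounds alone.

Compound 1 `CCC(=O)Nc1cccc(Oc2nc(Nc3ccc(N4CCC(OC)CC4)cc3OC)ncc2Cl)c1`: in an assay on isolated protein for inhibition of NUAK family SNF1-like kinase 2 (Homo sapiens), read by ADP-Glo, with a stated time of 60 min, tested at 10 uM, in the presence of a further agent that is not named here (on this read-out higher numbers stand for more inhibition at the one concentration tested (going by the name of the read-out) and lower numbers for less inhibition), compound 1 was reported as "not active" (no number reported), with no number given.
Compound 2 `CCC(=O)Nc1cccc(Oc2nc(Nc3ccc(N4CCC(OC)CC4)cc3)ncc2Cl)c1`: in this assay compound 2 gives 53.4%.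

Compound 2 holds the only number shown in this assay; compound 1 gave no number at all. Compound 3 `CCC(=O)Nc1cccc(Oc2nc(Nc3ccc(N4CCCC4)cc3)ncc2Cl)c1` differs from compound 2 by pyrrolidin-1-yl in place of 4-methoxypiperidin-1-yl on an aromatic carbon. Among the compounds with values here, no measured step between compounds is available to guide this change, so the expected step is small, in either direction, and may not exceed the usual scatter. Compound 3 is expected to give about 45%, with a range from 20% to 70%. This estimate means an expected step of a number 8.4 percentage points lower from compound 2 to compound 3 (within the scatter).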

Compound 3, a percentage reported as inhibition, at one concentration (the size of the read-out at that concentration, not a potency): "not active" (no number reported)
Nothing numeric was reported for compound 3, so the estimate cannot be set against anything.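

Within the data shown here, compound 3 carries no number, and no step from compound 2 to compound 3 can be read. Nothing measured here accounts for the result. The compounds shown leave open how inhibition responds to other ring amines in place of 4-methoxypiperidin-1-yl.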